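Moving the methoxy group: from compound 3 to compound 4

The source may report more compounds than this note shows. Statements on the series, on what has been measured and on what is new or still open speak of the compounds shown alone.

In a functional assay on HeLa cells (Homo sapiens) for antiproliferative activity, read by sulforhodamine B assay, with a stated time of 72 h (a higher number here means a weaker inhibitor, a lower number a stronger inhibitor), three compounds that share one core have been measured. Compound 1, `COc1ccccc1NC(=S)N/N=C/c1ccc2ccccc2n1`, reached only the limit of the assay, > 100000 nM, which is not a number; this is the limit of > 100000 nM in this assay, at which 1 of the 3 values shown sits. Compound 2, `N#Cc1ccc(NC(=S)N/N=C/c2ccc3ccccc3n2)cc1`, gives 20000 nM, and compound 3, `Cc1ccc(NC(=S)N/N=C/c2ccc3ccccc3n2)cc1`, gives 86000 nM. Among the two numbers given, compound 3 stands highest, with compound 2 nearest at a 4.3-fold higher number from compound 2 to compound 3 (0.63 log units; beyond the scatter). Against the limit of compound 1 the change is an at least 1.1-fold lower number from compound 1 to compound 3 (0.06 log units; that floor lies within the scatter), so that comparison says little.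

Compound 4, `COc1cccc(NC(=S)N/N=C/c2ccc3ccccc3n2)c1`, has not yet been measured. It differs from compound 3 as follows: 3-methoxyphenyl in place of 4-methylphenyl on an amide-type nitrogen. For the measured compounds named here, none of the measured steps repeats this exact change. The step of a 4.3-fold higher number from compound 2 to compound 3 (0.63 log units; beyond the scatter) shows that a different group on the phenyl ring can move the number modestly, while the step of an at least 1.1-fold lower number from compound 1 to compound 3 (0.06 log units; that floor lies within the scatter), which also exchanges a methoxyphenyl for a methylphenyl, gives only a floor that lies within the scatter. The step from compound 3 to compound 4 is therefore expected to be small, a 1.2-fold higher number from compound 3 to compound 4 (0.07 log units; within the scatter), with no clear direction beyond the scatter. Compound 4 is expected to give about 100000 nM, within a range from 40000 nM to 300000 nM, with a real chance that only the limit is reported.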

Compound 4, half-maximal inhibitory concentration: 74500 nM
Compound 4: the middle estimate sits 1.3-fold (0.13 log units) above what was measured, within the range that was stated.
By their numbers in this assay, from the lowest: compound 2; then compounds 4 and 3 (each within the scatter of the next). At a limit, above all of these: compound 1.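

In this assay, 3-methoxyphenyl in place of 4-methylphenyl on the amide-type nitrogen gives a 1.2-fold lower number from compound 3 to compound 4 (0.06 log units; within the scatter), so the two groups cannot be told apart, even though the entering group brings an oxygen and a hydrogen-bond acceptor that the leaving group lacks. 4-Cyanophenyl stays apart from both groups, with a 3.7-fold higher number from compound 2 to compound 4 (0.57 log units; beyond the scatter) alongside a 4.3-fold higher number from compound 2 to compound 3 (0.63 log units; beyond the scatter), so among the numbers shown only compound 2 is separated from the others beyond the scatter. Compound 1 carries a limit and not a number: the limit of > 100000 nM in this assay, at which 1 of the 4 values shown sits. That limit leaves only a floor, an at least 1.3-fold lower number from compound 1 to compound 4 (0.12 log units; that floor lies within the scatter), so the two methoxyphenyl placements cannot be compared.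

From the compounds shown here alone, whether the number of compound 2 belongs to the nitrile itself or to its place on the phenyl ring stays open. Also open, going by these compounds, is what a phenyl ring bearing an amine or a carboxylic acid would give on this nitrogen, and whether any such group would move the number as far as the nitrile does or stay with compounds 3 and 4.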